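The source may report more compounds than this note shows. Statements on the series, on what has been measured and on what is new or still open speak of the compounds shown alone.

Measured in a functional assay on ACHN cells (Homo sapiens) for inhibition, read by sulforhodamine B assay; a lower number here means a stronger inhibitor of growth, a higher number a weaker inhibitor of growth:
- Compound 1 `Cc1ccc(CN2CCC=C(CCC(=O)NO)C2=O)cc1`: 5000 nM
- Compound 2 `Cc1cccc(CN2CCC=C(CCC(=O)NO)C2=O)c1`: 4380 nM

Only these two compounds have been measured, so compound 1 has a single neighbour, and the two numbers lie within the usual scatter of each other. Compound 3 `O=C(CCC1=CCCN(Cc2ccc(NC(=O)c3ccccc3)cc2)C1=O)NO` keeps the core of compound 1 and changes one group: benzamido in place of methyl on an aromatic carbon, para to a large group (benzamido in place of methyl on an aromatic carbon).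

Among the measured compounds shown here, the one measured step that bears on this is a 1.1-fold lower number from compound 1 to compound 2 (0.06 log units; within the scatter). It only moved the methyl group, so it shows that this small shift hardly registers, but it says little about a far larger group. The data therefore give no firm direction. With much uncertainty, this assay is expected to show a modest move toward a lower number, estimated as a 2.5-fold lower number from compound 1 to compound 3 (0.40 log units; beyond the scatter). For compound 3 the estimated value is 2000 nM, with an expected range of 500 nM to 8000 nM.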

Compound 3, concentration for 50% growth inhibition: > 10000 nM
Compound 3 ended at the assay's limit (the forecaster's own chance of this, stated with the estimate: 10%); middle value at least 5.0-fold (0.69 log units) from the limit.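

In this assay, putting benzamido in place of methyl on the aromatic carbon gives an at least 2.0-fold higher number from compound 1 to compound 3 (0.30 log units; that floor lies within the scatter). Compound 3 reads > 10000 nM, which is a limit of the assay and not a number, so only the floor of this step is known, and that floor lies within the scatter. Compound 1 and compound 2 showed only that moving a methyl group hardly registers, whereas this change shows that a far larger group at this position brings no gain in growth inhibition and leaves compound 3 at the edge of what this assay can read: the limit of > 10000 nM in this assay, at which 1 of the 3 values shown sits.

The compounds shown leave open how a group of intermediate size on this carbon, such as methoxy or acetamido, would read. They also do not separate the part played by the amide link from that of the added aromatic ring, which a plain phenyl or an amine here could help to tell apart.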